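Swapping the aniline aryl group in a kinase series

This account rests on a few compounds, and the source may have more. Where it says the series, first, only, none or still open, it means among the compounds named here.

The study covers three close relatives sharing one core. Compound 1 `COc1cc(Nc2ncccc2-c2n[nH]c(Nc3ccc4c(c3)OCCO4)n2)cc(OC)c1` gives 83% in a functional assay on A-431 cells (Homo sapiens), tested at 0.1 uM; a lower number here means less inhibition, a higher number more inhibition at the concentration tested (going by the name of the read-out). Compound 2 `COc1cc(OC)cc(Oc2ncccc2-c2n[nH]c(Nc3ccc4c(c3)OCCO4)n2)c1` gives 89% in this assay, the higher of the two numbers, though a number 6 percentage points higher from compound 1 to compound 2 (within the scatter) lies within the scatter. Compound 3 `COc1cc(OC)cc(Oc2ncccc2-c2n[nH]c(Nc3cc(F)cc(F)c3)n2)c1` is not yet measured; it differs from compound 2 by 3,5-difluorophenyl in place of 2,3-dihydro-1,4-benzodioxin-6-yl on a nitrogen on an aromatic ring. Among the measured compounds shown here, no measured step touches this nitrogen-bound aryl group, so nothing in the data sizes the change, and the expectation rests only on compound 2. Compound 3 is expected to give 76% in this assay, within 50% to 92%, an estimated a number 13 percentage points lower from compound 2 to compound 3 (beyond the scatter).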

Compound 3, a percentage reported as inhibition, at one concentration (the size of the read-out at that concentration, not a potency): 27%
Compound 3: middle estimate off by 49 percentage points, on the high side, outside the stated range (below it).
By their numbers in this assay, from the lowest: compound 3; then compounds 1 and 2 (each within the scatter of the next).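

In this assay the aryl group on this nitrogen proves to matter: 3,5-difluorophenyl in place of 2,3-dihydro-1,4-benzodioxin-6-yl gives a number 62 percentage points lower from compound 2 to compound 3 (beyond the scatter). This is the first change among these compounds with an effect beyond the scatter. No evidence is available to explain the drop.

The compounds shown leave open whether the loss of the oxygen-bearing ring or the arrival of the two fluorines accounts for the step. An unsubstituted phenyl or a 3,4-dimethoxyphenyl on this nitrogen would help separate the two.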